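Pyrazin-2-yl in place of pyridin-2-yl on the shared core

The compounds below may be only part of what the source reports. "The series", "measured", "known", "first", "only" and "open" are said of these compounds alone.

Measured so far in an ADME assay on a cell-free system (plasma, Mus musculus) for metabolic stability, read by LC-MS, tested at 2 uM; on this read-out lower numbers stand for a shorter-lived compound and higher numbers for a longer-lived compound:
Compound 1 `COc1cc(-c2cn(C(=O)NCCCCc3ccccc3)c(=O)o2)ccc1F`: > 2 h (a limit of the assay)
Compound 2 `O=C(NCCCCc1ccccc1)n1cc(-c2ccccn2)oc1=O`: 0.667 h

For the measured compounds named here, compound 2, at 0.667 h, holds the only true number in this small set. Compound 1 stands at > 2 h, which is a limit and not a number.

The next structure is compound 3 `O=C(NCCCCc1ccccc1)n1cc(-c2cnccn2)oc1=O`, and the change to it is pyrazin-2-yl in place of pyridin-2-yl on an aromatic carbon. In words, it is pyrazin-2-yl in place of pyridin-2-yl on an aromatic carbon, next to the ring oxygen of the shared core.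

Going by the values given here, only one measured step bears on this. It is an at least 2.9-fold lower number from compound 1 to compound 2 (0.47 log units; beyond the scatter), and it came with pyridin-2-yl in place of 4-fluoro-3-methoxyphenyl on that same aromatic carbon. That step has one end at a limit and involves a different leaving group, so it offers a direction more than a size. On the strength of it, a small further move the same way is expected, and the estimated change is a 1.5-fold lower number from compound 2 to compound 3 (0.17 log units; within the scatter). For compound 3 the estimate in this assay is 0.45 h, with an expected range from 0.17 h to 1.1 h.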

Compound 3, half-life: 0.667 h
Compound 3: middle estimate off by 1.5-fold (0.17 log units), on the low side; the range from low to high includes it.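

At this aromatic carbon of the shared core, putting pyrazin-2-yl in place of pyridin-2-yl gives no change at the digits printed from compound 2 to compound 3 (within the scatter) in this assay, so a second hetero atom in the six-membered aromatic ring leaves the read-out where the first one had it. Set against the 4-fluoro-3-methoxyphenyl group, the pyrazin-2-yl group gives an at least 2.9-fold lower number from compound 1 to compound 3 (0.47 log units; beyond the scatter), which places the two nitrogen-bearing rings together on the same side of compound 1, whereas the earlier pair offered only one such ring. The true size of that step stays hidden, as the value of compound 1 is a limit of the assay: the limit of > 2 h in this assay, at which 1 of the 3 values shown sits.

The compounds shown leave open whether the step away from compound 1 follows the ring nitrogen or the loss of the fluoro and methoxy substituents, a question that a plain phenyl ring or a pyridin-2-yl ring carrying a methoxy group at this carbon would help to separate. They also leave open how a shorter chain in place of the four-carbon chain to the phenyl ring would read with either nitrogen-bearing ring in place.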